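Aryl ureas on a shared core: cytotoxicity notes

This account rests on a few compounds, and the source may have more. Where it says the series, first, only, none or still open, it means among the compounds named here.

Measured so far in an ADME assay on HEK293 cells (Homo sapiens) for cytotoxicity, with a stated time of 72 h; a lower number here means that less compound is needed, a higher number that more compound is needed for the effect:
- compound 1 `Cc1cc(NC(=O)Nc2cccc([N+](=O)[O-])c2)c2ccccc2n1`: a limit of the assay, > 25000 nM
- compound 2 `Cc1cc(NC(=O)Nc2cccc(F)c2)c2ccccc2n1`: a limit of the assay, > 25000 nM
- compound 3 `Cc1cc(NC(=O)Nc2ccccc2F)c2ccccc2n1`: a limit of the assay, > 25000 nM

All three readings sit at the same limit, so no number is known for any of them; the limit of > 25000 nM in this assay, at which 3 of the 3 values shown sit, is the whole of the evidence on this series. The step that the two limits leave unreadable from compound 2 to compound 1 cannot be read, and the change behind it is nitro in place of fluoro on an aromatic carbon. Likewise the step that the two limits leave unreadable from compound 2 to compound 3 cannot be read; here the two cores differ as 2-fluorophenyl in place of 3-fluorophenyl on an amide-type nitrogen.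

Compound 4 `Cc1cc(NC(=O)Nc2ccccc2[N+](=O)[O-])c2ccccc2n1` has not yet been measured. It differs from compound 3 as nitro in place of fluoro on an aromatic carbon. This is the same kind of change as that from compound 2 to compound 1, but not the same: in the earlier case the place is meta to a large group, here it is ortho to a large group. Since the earlier step is unreadable, nothing about its size carries over.

For compound 4 the expected step is a step that the limit leaves unreadable from compound 3 to compound 4, resting only on compound 3 having given > 25000 nM and on (the limit of > 25000 nM in this assay, at which 3 of the 3 values shown sit). Compound 4 is therefore estimated at 40000 nM, between 20000 nM and 90000 nM, most likely again reported only as a limit.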

Compound 4, half-maximal effective concentration: > 25000 nM
Compound 4: no number, only a limit; the forecaster's own chance of this, stated with the estimate: 85%; the middle value lies beyond the limit too.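

Compound 3 and compound 4 both stand only at a limit of the assay, so no step between them can be read, and the same holds for the earlier steps: the limit of > 25000 nM in this assay, at which 4 of the 4 values shown sit.

The compounds shown leave open whether any aryl urea on the shared core gives a real number in this assay, and whether nitro in place of fluoro changes that number.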